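Swapping the amide group of compound 3

The compounds below may be only part of what the source reports. "The series", "measured", "known", "first", "only" and "open" are said of these compounds alone.

In a functional assay on the whole organism for inhibition, with Cavia porcellus as the target (on this read-out higher numbers stand for an effect only at larger amounts of compound and lower numbers for an effect already at smaller amounts), three compounds that share one core differ only in the group on a carbonyl carbon. Compound 1 (`COc1ccccc1OCC1SCCN1C(=O)CC(=O)O`) gives 20 mg/kg and compound 2 (`CNC(=O)CC(=O)N1CCSC1COc1ccccc1OC`) gives 21 mg/kg as their doses for half-maximal effect. The change between them is a 1.1-fold higher number from compound 1 to compound 2 (0.02 log units; within the scatter) and so tells them apart by nothing. Compound 3 (`CCN(CC)CCNC(=O)CC(=O)N1CCSC1COc1ccccc1OC`) gives 56 mg/kg as the highest number of the three, which means it needs the largest dose. It lies modestly but clearly off the other two, as a 2.8-fold higher number from compound 1 to compound 3 (0.45 log units; beyond the scatter) and a 2.7-fold higher number from compound 2 to compound 3 (0.43 log units; beyond the scatter) show.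

Compound 4 (`COc1ccccc1OCC1SCCN1C(=O)CC(=O)N1CCN(C)CC1`) has not been measured yet. It carries 4-methylpiperazin-1-yl in place of (2-(diethylamino)ethyl)amino on a carbonyl carbon. Among the compounds with values here, no measured compound holds this new group, so the guidance is indirect. The same carbonyl carbon is the only place changed so far, and the changes there ranged from a 1.1-fold higher number from compound 1 to compound 2 (0.02 log units; within the scatter) up to a 2.8-fold higher number from compound 1 to compound 3 (0.45 log units; beyond the scatter) at most. A large jump therefore seems unlikely, and the number may drift back toward the lower pair. The expected step is a 1.6-fold lower number from compound 3 to compound 4 (0.20 log units; within the scatter) and it stays small, so no clear shift beyond the scatter is foreseen. In this assay the estimate for compound 4 is 35 mg/kg within an expected range of 14 mg/kg to 100 mg/kg around it.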

Compound 4, dose for half-maximal effect: 27 mg/kg
Beside the measured number, compound 4's estimate is 1.3-fold (0.11 log units) above it; the range from low to high includes it.
By their numbers in this assay, from the lowest: compounds 1, 2 and 4 (each within the scatter of the next); then compound 3.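

Replacing the open-chain (2-(diethylamino)ethyl)amino group with the 4-methylpiperazin-1-yl ring on this carbonyl carbon in this assay gives a 2.1-fold lower number from compound 3 to compound 4 (0.32 log units; beyond the scatter), so the higher number of compound 3 does not come with every group that holds two nitrogens. Compound 4 also stays within the scatter of the two simpler compounds, with a 1.3-fold higher number from compound 2 to compound 4 (0.11 log units; within the scatter) and a 1.4-fold higher number from compound 1 to compound 4 (0.13 log units; within the scatter), which leaves hydroxy, methylamino and 4-methylpiperazin-1-yl unseparated here despite their different shapes, and only the (2-(diethylamino)ethyl)amino group of compound 3 stands apart. No accompanying data offer an explanation for this difference.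

The ring, the missing amide hydrogen and the smaller count of heavy atoms all change together from compound 3 to compound 4, so the step cannot be assigned to any one of them. From the compounds shown here alone, a morpholine ring, which has oxygen in place of the methyl-bearing nitrogen, or an open chain ending in a dimethylamino group, could help separate these features, while every change shown sits at this one carbonyl carbon and the rest of the shared core remains unexplored here.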